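Piperidinyl in Place of Trifluoropropyl: An Expected Gain

The source may report more compounds than this note shows. Statements on the series, on what has been measured and on what is new or still open speak of the compounds shown alone.

Compound 1 `CC(C)n1nc(C(=O)N[C@H]2COc3ccccc3N(C)C2=S)nc1Cc1ccccc1`: 360 nM
Compound 2 `CN1C(=S)[C@@H](NC(=O)c2nc(Cc3ccccc3)n(CCC(F)(F)F)n2)COc2ccccc21`: 1550 nM
Compound 3 `CN1C(=S)[C@@H](NC(=O)c2nc(Cc3ccccc3)n(C3CCC3)n2)COc2ccccc21`: 181 nM

These three compounds share one core and differ only in the group on an aromatic nitrogen. In a functional assay on HT-29 cells (Homo sapiens) for inhibition, read by luminescence and CellTiter-Glo, with a stated time of 24 h (on this read-out higher numbers stand for an effect only at larger amounts of compound and lower numbers for an effect already at smaller amounts), compound 2 gives the highest of the three numbers. The change to compound 4 `CN1C(=S)[C@@H](NC(=O)c2nc(Cc3ccccc3)n(C3CCNCC3)n2)COc2ccccc21` is piperidin-4-yl in place of 3,3,3-trifluoropropyl on an aromatic nitrogen. For the measured compounds named here, two measured steps bear on it: an 8.6-fold lower number from compound 2 to compound 3 (0.93 log units; beyond the scatter), and a 4.3-fold higher number from compound 1 to compound 2 (0.63 log units; beyond the scatter), which runs the other way from the step considered here. Both show the trifluoropropyl group of compound 2 linked to higher numbers than the isopropyl and cyclobutyl groups. A step to a lower number is therefore expected, a 3.9-fold lower number from compound 2 to compound 4 (0.59 log units; beyond the scatter), though the entering group matches neither measured one. Compound 4 is estimated at 400 nM, within 120 nM to 1500 nM.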

Compound 4, half-maximal effective concentration: 1000 nM
The estimate for compound 4 lay 2.5-fold (0.40 log units) below the measured number; the measured number falls inside the stated range.
By their numbers in this assay, from the lowest: compounds 3 and 1 (each within the scatter of the next); then compounds 4 and 2 (each within the scatter of the next).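

In this assay the piperidin-4-yl group falls short of the cyclobutyl and isopropyl groups, with a 5.5-fold higher number from compound 3 to compound 4 (0.74 log units; beyond the scatter) and a 2.8-fold higher number from compound 1 to compound 4 (0.44 log units; beyond the scatter) both beyond the usual scatter. Against trifluoropropyl, a 1.6-fold lower number from compound 2 to compound 4 (0.19 log units; within the scatter) lies within the scatter, so these two groups cannot be told apart here, although only piperidin-4-yl brings a ring nitrogen. Nothing available accounts for this pattern.

Still open, from the compounds shown here alone, is whether a piperidine with a methyl group on its nitrogen, or an open-chain amine, would sit with compound 4 or with compound 3.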